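The compounds below may be only part of what the source reports. "The series", "measured", "known", "first", "only" and "open" are said of these compounds alone.

Measured compounds in a functional assay on HCT-116 cells (Homo sapiens) for inhibition, read by sulforhodamine B assay, with a stated time of 72 h; a higher number here means a weaker inhibitor, a lower number a stronger inhibitor:

Compound 1, `COc1ccc2cc(C(C)c3nnc4n3N=C(c3ccc(F)cc3)CS4)ccc2c1`: 13100 nM
Compound 2, `COc1ccc(C2=Nn3c(nnc3C(C)c3ccc4cc(OC)ccc4c3)SC2)cc1`: 6500 nM
Compound 3, `COc1ccc(C2=Nn3c(nnc3C(C)c3ccc(CC(C)C)cc3)SC2)cc1`: 4200 nM

Compound 3 gives the lowest of the three numbers, but its gap to compound 2 is within the scatter; only its gap to compound 1 lies beyond it. Compound 2 and compound 1 share a core and differ only by fluoro in place of methoxy on an aromatic carbon; that change gave a 2.0-fold higher number from compound 2 to compound 1 (0.30 log units; within the scatter). The difference between the cores of compound 3 and compound 2 is not broken down here.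

Compound 4, `CC(C)Cc1ccc(C(C)c2nnc3n2N=C(c2ccc(F)cc2)CS3)cc1`, is not yet measured. It differs from compound 3 by fluoro in place of methoxy on an aromatic carbon, and the place is the same, word for word, as in the change from compound 2 to compound 1, so it is the same change made on the core of compound 3.

Going by the values given here, the step from compound 3 to compound 4 is expected to be a 1.9-fold higher number from compound 3 to compound 4 (0.28 log units; within the scatter) because a 2.0-fold higher number from compound 2 to compound 1 (0.30 log units; within the scatter) was seen for the same change, and no second example exists to sharpen the expectation. For compound 4 the estimated value in this assay is 8000 nM, with a likely range from 3500 nM to 18000 nM.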

Compound 4, half-maximal inhibitory concentration: 12400 nM
Beside the measured number, compound 4's estimate is 1.6-fold (0.19 log units) below it; the measured number falls inside the stated range.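

In this assay, fluoro in place of methoxy gives a 3.0-fold higher number from compound 3 to compound 4 (0.47 log units; beyond the scatter), the same direction as on the core of compound 2, where the step alone stayed within the scatter. Carried across these two cores, the change gives steps that cannot be told apart in size: the same change on two cores in this assay, a 2.0-fold higher number (0.30 log units; within the scatter) from compound 2 to compound 1 and a 3.0-fold higher number (0.47 log units; beyond the scatter) from compound 3 to compound 4, 1.5-fold (0.17 log units) apart, within the scatter of two such steps. This supports transfer of the 4-methoxyphenyl to 4-fluorophenyl change between these two cores only; two examples set no rule for the series, and the numbers do not say why the fluoro compounds give higher values.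

The compounds shown carry only methoxy or fluoro at this place, so the effect of a hydroxyl, an amine or a carboxylic acid there remains open. Also open, going by these compounds, is whether the step holds on a third core, for instance one with a longer chain in place of the isobutyl-bearing part of compound 3.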